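The source may hold more compounds than are shown below. What is called first, only, known or untested is meant among the compounds shown, and "the series" means these compounds.

Working notes on a functional assay on G-361 cells (Homo sapiens) for cytotoxicity, read by MTT assay, with a stated time of 3 days; on this read-out higher numbers stand for weaker inhibition and lower numbers for stronger inhibition. In this assay, for the measured compounds named here, compound 1 `N#Cc1c(NN)nc(SCc2nc3ccccc3[nH]2)nc1-c1ccccc1` gives 14.7 nM, and compound 2 `N#Cc1c(Nc2ccccc2)nc(SCc2nc3ccccc3[nH]2)nc1-c1ccccc1` gives 2.4 nM, the lowest of the two numbers so far. The next structure is compound 3 `CNc1nc(SCc2nc3ccccc3[nH]2)nc(-c2ccccc2)c1C#N`, with methyl in place of phenyl on a nitrogen on an aromatic ring. Going by the values given here, one measured step bears on this change: a 6.1-fold lower number from compound 1 to compound 2 (0.79 log units; beyond the scatter), where phenyl in place of amino on a nitrogen on an aromatic ring came with a lower number, beyond the scatter. On that single step, losing the phenyl is expected to raise the number in this assay by a similar or somewhat smaller amount, though the support is thin. The expected step is a 3.8-fold higher number from compound 2 to compound 3 (0.57 log units; beyond the scatter). For compound 3 the estimated value is 9 nM, with an expected range of 3 nM to 30 nM.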

Compound 3, half-maximal inhibitory concentration: 12.5 nM
Compound 3: the middle estimate sits 1.4-fold (0.14 log units) below what was measured; the measured number falls inside the stated range.
By their numbers in this assay, from the lowest: compound 2; then compounds 3 and 1 (each within the scatter of the next).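

In this assay there is a 5.2-fold higher number from compound 2 to compound 3 (0.72 log units; beyond the scatter), so the low number of compound 2 now stands against two small groups on this nitrogen rather than one. Methyl and amino on this nitrogen are not told apart, with a 1.2-fold lower number from compound 1 to compound 3 (0.07 log units; within the scatter), so among these three compounds only the phenyl goes with a shift beyond the scatter, and compound 2 remains the most potent of them. No measurement on hand explains this difference.

Still open, as far as these compounds go, is whether the aromatic ring itself matters or whether another six-carbon group would serve as well; cyclohexyl on this nitrogen would separate these two readings. A longer chain such as butyl, or benzyl, would show whether the number moves gradually between methyl and phenyl.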